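This account rests on a few compounds, and the source may have more. Where it says the series, first, only, none or still open, it means among the compounds named here.

Among the compounds with values here, in a functional assay on A549 cells (Homo sapiens) for cytotoxicity, read by MTT assay (on this read-out lower numbers stand for stronger inhibition and higher numbers for weaker inhibition), compound 1 `COC(=O)C[C@H]1C[C@H](O)[C@@H](C)[C@@H](c2ccc(C)cc2)N1` gives 97600 nM, the higher of the two numbers measured so far. Compound 2 `COC(=O)C[C@H]1C[C@@H](O)[C@@H](C)[C@@H](c2ccc(OC)cc2)N1` gives 23500 nM, and the gap between them lies beyond the usual scatter, so compound 1 is the weaker of the pair on this read-out. The next compound, compound 3 `COC(=O)C[C@H]1C[C@H](O)[C@@H](C)[C@@H](c2ccc(F)cc2)N1`, keeps the core of compound 1 and changes one group: it has fluoro in place of methyl on an aromatic carbon of a six-membered aromatic ring of carbon only, para to a large group (fluoro in place of methyl on an aromatic carbon). Within the data shown here, no measured pair shows what a single change of this kind does, so any expectation here is loose. In this assay only a small step is expected, most likely not beyond the scatter. It should lean towards a lower number, since compound 1 at 97600 nM already stands at the top of the measured values. The expected change is a 1.4-fold lower number from compound 1 to compound 3 (0.14 log units; within the scatter). For compound 3 the estimated value is 70000 nM, with an expected range of 25000 nM to 200000 nM.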

Compound 3, half-maximal inhibitory concentration: 17200 nM
Beside the measured number, compound 3's estimate is 4.1-fold (0.61 log units) above it; measured number outside the range, below it.
By their numbers in this assay, from the lowest: compounds 3 and 2 (each within the scatter of the next); then compound 1.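

In this assay, placing fluoro in place of methyl on an aromatic carbon, para to a large group, gives a 5.7-fold lower number from compound 1 to compound 3 (0.75 log units; beyond the scatter) with the rest of compound 1 unchanged. Within the data shown here, this is the first measured pair that differs in only one place, so it gives the first direct reading of this position; compounds 1 and 2 differ in more than one place and could not show this. The step shows that exchanging one heavy atom here can move the number beyond the scatter, even though the two groups have the same counts of heavy atoms, hydrogen-bond donors and hydrogen-bond acceptors, and no measurement at hand accounts for the step.

A single pair cannot show whether the number falls with fluoro specifically or with the removal of methyl, or how chloro, a hydroxyl group or an amine at this place would compare. It also leaves open whether the same exchange would give a similar step in a compound with the spatial arrangement at the hydroxyl-bearing carbon found in compound 2.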